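A few compounds are considered here, and "the series" means these few. Any claim that something is new, unique, unknown or untested is made for them only; others in the source may bear on it.

Measured compounds:
compound 1 `Cc1cc(NCc2ccccn2)n2ncc(-c3ccn(C)n3)c2n1`, 188000 nM
compound 2 `Cc1cc(NCc2ccccn2)n2ncc(C3=CCC(F)(F)CC3)c2n1`, 5000 nM
compound 3 `Cc1cc(NCc2ccccn2)n2ncc(-c3ccc(O)cc3)c2n1`, 10900 nM

In a physicochemical assay for solubility, read by HPLC, using the shake flask method, measured as kinetic solubility, with a stated time of 2 h, at pH 7.4 (a higher number here means a more soluble compound, a lower number a less soluble compound), compound 3 stands second highest of the three. It sits far under compound 1 by a 17-fold lower number from compound 1 to compound 3 (1.24 log units; beyond the scatter) and somewhat over compound 2 by a 2.2-fold higher number from compound 2 to compound 3 (0.34 log units; beyond the scatter). Compound 4 `Cc1cc(NCc2ccccn2)n2ncc(-c3ccc(F)cc3C)c2n1` differs from compound 3 in one place: 4-fluoro-2-methylphenyl in place of 4-hydroxyphenyl on an aromatic carbon. Among the measured compounds shown here, the step that bears most on this is the one between compound 2 and compound 3, where a group without donor or acceptor gave the lower number. The step from compound 1 to compound 3 points the same way but is larger. A modest fall is therefore expected, roughly matching compound 2. Compound 4 is estimated at 3500 nM, within 900 nM to 13000 nM, an expected step of a 3.1-fold lower number from compound 3 to compound 4 (0.49 log units; beyond the scatter).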

Compound 4, solubility: 42300 nM
For compound 4 the middle estimate is 12-fold (1.08 log units) below the measured one; the measured number lies above the stated range.
By their numbers in this assay, from the lowest: compound 2; then compound 3; then compound 4; then compound 1.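

In this assay, putting 4-fluoro-2-methylphenyl, with 0 hydrogen-bond donors and 0 acceptors, in place of 4-hydroxyphenyl on this aromatic carbon gives a 3.9-fold higher number from compound 3 to compound 4 (0.59 log units; beyond the scatter). Against 4,4-difluorocyclohex-1-en-1-yl, the same group gives an 8.5-fold higher number from compound 2 to compound 4 (0.93 log units; beyond the scatter), while 1-methyl-1H-pyrazol-3-yl keeps the highest number, with a 4.4-fold lower number from compound 1 to compound 4 (0.65 log units; beyond the scatter). No measurement here explains why the number rises on removing the hydroxyl-bearing ring. The compounds shown leave open whether the fluorine or the methyl accounts for the rise, and how a phenyl ring carrying an amine or a carboxylic acid would compare.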